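The source may hold more compounds than are shown below. What is called first, only, known or untested is meant among the compounds shown, and "the series" means these compounds.

Working notes on the series.

The shared core is kept throughout; only the group on the amine nitrogen changes. Compound 1 `CCc1ccc(NC2=CC(=O)c3c(nc4n3[C@H]3OC[C@@H](O)[C@H]3OC4)C2=O)cc1` carries a 4-ethylphenyl there and gives 1110 nM in a functional assay on MGC-803 cells (Homo sapiens) for inhibition, read by sulforhodamine B assay; a higher number here means a weaker inhibitor, a lower number a stronger inhibitor. Compound 2 `CCOc1ccc(NC2=CC(=O)c3nc4n(c3C2=O)[C@H]2OC[C@@H](O)[C@H]2OC4)cc1` gives 1110 nM, the same number at the digits shown as compound 1. Going by the values given here, compound 3 `CCOc1ccccc1NC1=CC(=O)c2nc3n(c2C1=O)[C@H]1OC[C@@H](O)[C@H]1OC3` gives 2450 nM; the step of a 2.2-fold higher number from compound 2 to compound 3 (0.34 log units; beyond the scatter) is the only measured step in the set, and it moves the ethoxy group around the phenyl ring rather than replacing the ring.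

Compound 4 `O=C1C(NC2CC2)=CC(=O)c2c1nc1n2[C@H]2OC[C@@H](O)[C@H]2OC1` differs from compound 1 by cyclopropyl in place of 4-ethylphenyl on an amine nitrogen. Among the compounds with values here, no measured pair replaces the aromatic ring with a small non-aromatic ring, so the step from compound 2 to compound 3 bears on it only loosely, showing that even a modest change on the amine nitrogen can move the number beyond the scatter. With the phenyl ring gone, a weaker inhibitor is expected, a step of a 2.7-fold higher number from compound 1 to compound 4 (0.43 log units; beyond the scatter), with wide uncertainty. Compound 4 is estimated at 3000 nM, within 1000 nM to 10000 nM.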

Compound 4, half-maximal inhibitory concentration: > 4000 nM
Compound 4: a limit, no number (the forecaster's own chance of this, stated with the estimate: 10%); middle value at least 1.3-fold (0.12 log units) away from the limit.
By their numbers in this assay, from the lowest: compounds 1 and 2 (each within the scatter of the next); then compound 3. At a limit, above all of these: compound 4.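

Compound 4 gives only a limit in this assay, > 4000 nM, not a number. Cyclopropyl in place of 4-ethylphenyl on the amine nitrogen gives an at least 3.6-fold higher number from compound 1 to compound 4 (0.55 log units; beyond the scatter), so, unlike the shift of the ethoxy group around the phenyl ring, this change removes the aromatic ring itself and still costs inhibition in this assay. The full size of the step stays unknown, as the reading stops at a limit: the limit of > 4000 nM in this assay, at which 1 of the 4 values shown sits.

The change in compound 4 swaps the aromatic ring for a non-aromatic one and shortens the group in the same step, so the two cannot be told apart. On these data alone, a cyclohexyl ring or an unsubstituted phenyl ring on the same nitrogen would bear on that question, and how either reads here remains open.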